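A few compounds are considered here, and "the series" means these few. Any claim that something is new, unique, unknown or untested is made for them only; others in the source may bear on it.

Measured compounds in a physicochemical assay for lipophilicity, measured as octanol-water partition; a lower number here means a more polar compound, a higher number a more lipophilic compound:
compound 1 `O=C(NNc1ccnc2cc(Cl)ccc12)c1ccccc1/N=C/c1ccc(F)cc1`, with a value of 5.18;
compound 2 `O=C(NNc1ccnc2cc(Cl)ccc12)c1ccccc1/N=C/c1ccccc1Cl`, with a value of 5.5;
compound 3 `O=C(NNc1ccnc2cc(Cl)ccc12)c1ccccc1/N=C/c1ccc(O)cc1`, with a value of 4.65.

Compound 2 stands highest of the three: compound 1 is nearest, and the step from compound 1 to compound 2 is a number 0.32 log units higher from compound 1 to compound 2 (beyond the scatter), while compound 3 is furthest, the step from compound 2 to compound 3 being a number 0.85 log units lower from compound 2 to compound 3 (beyond the scatter). The step from compound 1 to compound 3 is a number 0.53 log units lower from compound 1 to compound 3 (beyond the scatter).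

Compound 4 `CN(C)c1ccc(/C=N/c2ccccc2C(=O)NNc2ccnc3cc(Cl)ccc23)cc1` has not been measured. It differs from compound 2 as follows: 4-(dimethylamino)phenyl in place of 2-chlorophenyl on a carbon with a double bond to nitrogen.

Both measured departures from the 2-chlorophenyl group of compound 2 lowered the number in this assay, the larger one being the move to the 4-hydroxyphenyl group of compound 3. Within the data shown here, the entering 4-(dimethylamino)phenyl group brings one hydrogen-bond acceptor and no donor, and no measured step covers exactly this group. Among the measured compounds shown here, a modest downward step is therefore expected for compound 4, of about a number 0.50 log units lower from compound 2 to compound 4 (beyond the scatter), smaller than the one to compound 3. Compound 4 is estimated at 5, in a range from 4.5 to 5.5.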

Compound 4, partition coefficient: 5.03
Compound 4: middle estimate off by 0.03 log units, on the low side; measured number inside the range.
By their numbers in this assay, from the lowest: compound 3; then compounds 4 and 1 (each within the scatter of the next); then compound 2.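

In this assay, the carbon with a double bond to nitrogen now carries a third group in place of 2-chlorophenyl: the 4-(dimethylamino)phenyl group gives a number 0.47 log units lower from compound 2 to compound 4 (beyond the scatter), so compounds 1, 3 and 4 all stand lower than compound 2, even though this entering group has more heavy atoms than the one it replaces. Among the groups on the aromatic carbon, dimethylamino in place of hydroxy gives a number 0.38 log units higher from compound 3 to compound 4 (beyond the scatter), while dimethylamino in place of fluoro gives a number 0.15 log units lower from compound 1 to compound 4 (within the scatter), so compounds 1 and 4 cannot be told apart and compound 3 alone stands apart from them. No independent measurement bears on what lies behind these differences.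

From the compounds shown here alone, it remains open whether a carboxylic acid or a morpholine on the aromatic ring, or a cyclohexyl group in place of that ring, would fall with compound 3 or with compounds 1 and 4. Also open, going by these compounds, is where a 4-chlorophenyl group would stand, as compounds 1 and 2 differ in both the halogen and its place on the ring.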